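Branching at the benzylic chain carbon in the spiro-imidazolone series

The compounds below may be only part of what the source reports. "The series", "measured", "known", "first", "only" and "open" are said of these compounds alone.

Three compounds have numbers in a functional assay on CHO cells for antagonist activity at Glucagon receptor (Homo sapiens), read by cAMP accumulation, with stated times of 30 min and 45 min; a higher number here means a weaker inhibitor, a lower number a stronger inhibitor. Compound 1 `CC1(CC[C@H](c2ccc(C(=O)NCc3nn[nH]n3)cc2)N2C(=O)C(c3cc(Cl)cc(Cl)c3)=N[C@]23CC[C@@H](C(C)(C)C)CC3)CC1` gives 100 nM. Compound 2 `CC(C)(C)[C@H]1CC[C@]2(CC1)N=C(c1ccc(Cl)cc1)C(=O)N2Cc1ccc(C(=O)NCCC(=O)O)cc1` gives 1400 nM. Compound 3 `CC(C)[C@H](c1ccc(C(=O)NCc2nn[nH]n2)cc1)N1C(=O)C(c2cc(Cl)cc(Cl)c2)=N[C@]12CC[C@@H](C(C)(C)C)CC2` gives 2200 nM, the highest of the three numbers; compound 2 lies within the scatter of it, while compound 1 stands well apart at a lower number.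

Compound 4 `CCC[C@H](c1ccc(C(=O)NCc2nn[nH]n2)cc1)N1C(=O)C(c2cc(Cl)cc(Cl)c2)=N[C@]12CC[C@@H](C(C)(C)C)CC2` is not yet measured. It differs from compound 3 by propyl in place of isopropyl on a saturated chain carbon bound to an amide-type nitrogen in a ring and an aromatic carbon. The two have the same atoms, joined differently.

For the measured compounds named here, the one measured step that bears on this position is a 22-fold higher number from compound 1 to compound 3 (1.34 log units; beyond the scatter): the branched isopropyl is far weaker than the longer chain. That step compares different sizes of group, not branching alone, so it is only an indirect guide. Still, it shows the position is sensitive, and that moving away from isopropyl can lower the number greatly. A moderate drop beyond the scatter is therefore expected, a 3.1-fold lower number from compound 3 to compound 4 (0.50 log units; beyond the scatter). Compound 4 is estimated at 700 nM in this assay, with a range from 250 nM to 2000 nM.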

Compound 4, half-maximal inhibitory concentration: 220 nM
Estimate against measurement, compound 4: 3.2-fold (0.50 log units) above; the whole stated range lies above it.
By their numbers in this assay, from the lowest: compound 1; then compound 4; then compounds 2 and 3 (each within the scatter of the next).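

In this assay, with the atoms unchanged, the branch at the saturated chain carbon accounts for a large share of the loss seen in compound 3: propyl in place of isopropyl gives a 10-fold lower number from compound 3 to compound 4 (1.00 log units; beyond the scatter). The earlier step mixed branching with chain size, whereas the unbranched chain now separates the two, and methyl in place of 1-methylcyclopropyl at the chain end accounts for a smaller part, a 2.2-fold higher number from compound 1 to compound 4 (0.34 log units; beyond the scatter). Nothing available gives a cause for either step.

Open, from the compounds shown here alone, is how the number responds to a shorter or longer unbranched chain, such as ethyl or butyl, at this carbon. Also open, going by these compounds, is whether a simpler branch further along the chain, as in isobutyl, or an amine at the chain end would hold the number near that of compound 1.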